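Trifluoromethyl to Bromo on a Shared Steroid-Like Core

This account rests on a few compounds, and the source may have more. Where it says the series, first, only, none or still open, it means among the compounds named here.

Of the compounds shown here, two have been measured here. Compound 2 `C=C1C[C@]23C[C@@]1(O)CC[C@H]2c1ccc(O)c(C)c1[C@@H]3Cn1cc(-c2ccc(C(F)(F)F)cc2)nn1` and compound 1 `C=C1C[C@]23C[C@@]1(O)CC[C@H]2c1ccc(OS(=O)(=O)c2ccc(C)cc2)c(C)c1[C@@H]3Cn1cc(-c2ccc(Br)cc2)nn1` were both tested in a functional assay on HL-60 cells (Homo sapiens) for cytotoxicity, read by MTT assay, with a stated time of 4 days; a lower number here means a stronger inhibitor, a higher number a weaker inhibitor. In this assay, within the data shown here, compound 2 gives 8950 nM, which is the only actual number in the set. For compound 1 the result in this assay is a limit of the assay rather than a number, reported as > 20000 nM. Put differently, one of the two results is the limit of > 20000 nM in this assay, at which 1 of the 2 values shown sits, so compound 2 stands alone as the sole measured value.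

Compound 3 `C=C1C[C@]23C[C@@]1(O)CC[C@H]2c1ccc(O)c(C)c1[C@@H]3Cn1cc(-c2ccc(Br)cc2)nn1` differs from compound 2 in a single place: bromo in place of trifluoromethyl on an aromatic carbon. Among the measured compounds shown here, no measured pair of compounds differs in exactly this way, so the size of the step cannot be read from the data; compound 1 carries the same bromo group but also differs elsewhere, and only its limit is known.

With nothing to point to, the expected change from compound 2 to compound 3, a 1.1-fold higher number from compound 2 to compound 3 (0.05 log units; within the scatter), is estimated to stay within the usual scatter, in no particular direction. Compound 3 is therefore expected to give about 10000 nM in this assay, with a likely range from 4000 nM to 25000 nM.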

Compound 3, half-maximal inhibitory concentration: > 20000 nM
Compound 3 ended at the assay's limit; the forecaster's own chance of this, stated with the estimate: 25%; middle value at least 2.0-fold (0.30 log units) from the limit.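

The change from 4-(trifluoromethyl)phenyl to 4-bromophenyl gives an at least 2.2-fold higher number from compound 2 to compound 3 (0.34 log units; beyond the scatter) in this assay, so a higher number here means a weaker inhibitor and this position is sensitive to which group sits on it. Compound 3 gives > 20000 nM, which is a limit of the assay, so the step has a known lower bound but no known full size. The step that removes (4-methylphenyl)sulfonyl from the oxygen cannot be read, and compound 1 and compound 3 share the same ceiling: the limit of > 20000 nM in this assay, at which 2 of the 3 values shown sit.

The compounds shown do not reveal whether bromo is specifically unfavourable or whether trifluoromethyl is unusually well suited to this position, and a chloro, methoxy, amine or carboxylic acid group in the same place would help separate those two readings. From the compounds shown here alone, with only compound 2 giving an actual number, it also remains open whether any replacement at this position can produce a lower number than compound 2 does.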